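The compounds below may be only part of what the source reports. "The series", "measured", "known", "first", "only" and "open" are said of these compounds alone.

Measured compounds:
compound 1 `Cc1nc(Nc2ccccc2)sc1C(=O)/C=C/c1ccc(Cl)cc1` — > 25000 nM
compound 2 `Cc1cccc(Nc2nc(C)c(C(=O)/C=C/c3ccccc3)s2)c1` — > 25000 nM

In a functional assay on Bel-7402 cells (Homo sapiens) for cytotoxicity, read by MTT assay (on this read-out lower numbers stand for stronger inhibition and higher numbers for weaker inhibition), compound 1 reaches only a limit of the assay, > 25000 nM. In this assay compound 2 likewise gives only a limit, > 25000 nM. Compound 2 thus stands at the limit of > 25000 nM in this assay, at which 2 of the 2 values shown sit; no numerical value separates it from compound 1, and neither can be ranked against the other. Going by the values given here, no step between measured compounds can be formed.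

Compound 3 `Cc1nc(Nc2ccccc2)sc1C(=O)/C=C/c1ccccc1` differs from compound 2 by hydrogen in place of methyl on an aromatic carbon, a hydrogen in place of methyl on an aromatic carbon. Since compound 2 sits at > 25000 nM, the removal of one methyl from the anilino part starts from a limit, and it is expected to shift the read-out little, in no fixed direction. For compound 3 in this assay the expected value is 30000 nM, within 12000 nM to 80000 nM, most likely again reported only as a limit. The expected step that the limit leaves unreadable from compound 2 to compound 3 is none beyond the scatter.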

Compound 3, half-maximal inhibitory concentration: > 25000 nM
Compound 3 was reported as a limit; the forecaster's own chance of this, stated with the estimate: 85%; the middle value is on the limit's open side.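

No step among compound 1, compound 2 and compound 3 can be read: the limit of > 25000 nM in this assay, at which 3 of the 3 values shown sit.

The compounds shown leave open whether methyl or chloro in place of hydrogen on an aromatic carbon changes the read-out in this assay, and whether any compound of this series gives a numerical value.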